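The compounds below may be only part of what the source reports. "The series", "measured", "known", "first", "only" and "open" are said of these compounds alone.

Compound 2 `COc1cc(-c2nn(-c3cccc(NC(=O)Nc4cc(C(F)(F)F)cc(C(F)(F)F)c4)c3)cc2-c2ccncc2)ccc1Cl` shows the lower of the two numbers in a functional assay on HOP-92 cells (Homo sapiens) for inhibition, read by sulforhodamine B assay, with a stated time of 48 h; on this read-out lower numbers stand for stronger inhibition and higher numbers for weaker inhibition: compound 2 gives 140 nM, while compound 1 `O=C(Nc1cccc(-n2cc(-c3ccncc3)c(-c3ccc(Cl)c(O)c3)n2)c1)Nc1cccc(C(F)(F)F)c1` gives 510 nM, and that gap lies beyond the scatter. Compound 3 `O=C(Nc1cccc(-n2cc(-c3ccncc3)c(-c3ccc(Cl)c(O)c3)n2)c1)Nc1cc(C(F)(F)F)cc(C(F)(F)F)c1` has not been measured. It differs from compound 2 by hydrogen in place of methyl on an oxygen on an aromatic ring, that is, methoxy to hydroxy; 4-chloro-3-methoxyphenyl to 4-chloro-3-hydroxyphenyl. Within the data shown here, with no matched pair in this assay showing that change, only a small step is expected, from compound 2 to compound 3 estimated as a 1.8-fold higher number from compound 2 to compound 3 (0.25 log units; within the scatter), in either direction, not clearly beyond the scatter. For compound 3 the estimated value in this assay is 250 nM, between 80 nM and 800 nM.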

Compound 3, half-maximal inhibitory concentration: 340 nM
Estimate against measurement, compound 3: 1.4-fold (0.13 log units) below, within the range that was stated.
By their numbers in this assay, from the lowest: compound 2; then compounds 3 and 1 (each within the scatter of the next).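

In this assay, the methoxy to hydroxy change on the aromatic ring gives a 2.4-fold higher number from compound 2 to compound 3 (0.39 log units; beyond the scatter), a modest but readable loss at this position. With the hydroxy kept, trifluoromethyl in place of hydrogen on an aromatic carbon gives a 1.5-fold lower number from compound 1 to compound 3 (0.18 log units; within the scatter), so that change cannot be told apart from the scatter. Nothing given here accounts for either step. On these data alone, it remains open how an amine or an ethoxy group in place of the hydroxy would read, and whether the trifluoromethyl step would hold with methoxy present.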